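Longer Chain, New End Group: Expectations for Compound 4

The source may hold more compounds than are shown below. What is called first, only, known or untested is meant among the compounds shown, and "the series" means these compounds.

Measured in a functional assay on HCT-116 cells (Homo sapiens) for inhibition, read by MTT assay, with a stated time of 72 h (a lower number here means a stronger inhibitor, a higher number a weaker inhibitor), as follows
- compound 1 `Nc1ncnc2c1c(-c1cnc3[nH]ccc3c1)nn2CCCCCCC(=O)NO`: 9860 nM
- compound 2 `Nc1nc2cc(-c3nn(CCCCC(=O)NO)c4ncnc(N)c34)ccc2o1`: 34000 nM
- compound 3 `Nc1ncnc2c1c(-c1cnc3[nH]ccc3c1)nn2CCCC(=O)NO`: > 150000 nM (a limit of the assay, not a number)

Of the two true numbers, compound 2 has the higher, beyond the scatter from compound 1. Compound 4 `CNC(=O)CCCCCCCn1nc(-c2ccc3oc(N)nc3c2)c2c(N)ncnc21` differs from compound 2 by 3-(methylcarbamoyl)propyl in place of hydroxycarbamoyl on a saturated chain carbon, four bonds along the chain from an aromatic nitrogen and carries 3-(methylcarbamoyl)propyl in place of hydroxycarbamoyl. Among the compounds with values here, the one measured step that bears on this is large: an at least 15-fold higher number from compound 1 to compound 3 (1.18 log units; beyond the scatter) shortens the chain while keeping the hydroxycarbamoyl end. Within the data shown here, compound 4 instead lengthens the chain, but no measured step covers the loss of that end. The estimated change is therefore a smaller move to a lower number, a 3.8-fold lower number from compound 2 to compound 4 (0.58 log units; beyond the scatter) in this assay as expected. For compound 4 the estimate is 9000 nM with an expected range of 1200 nM to 70000 nM in this test.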

Compound 4, half-maximal inhibitory concentration: 3150 nM
The estimate for compound 4 lay 2.9-fold (0.46 log units) above the measured number; low and high end bracket the measured number.
By their numbers in this assay, from the lowest: compound 4; then compound 1; then compound 2. At a limit, above all of these: compound 3.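

Swapping hydroxycarbamoyl for 3-(methylcarbamoyl)propyl gives an 11-fold lower number from compound 2 to compound 4 (1.03 log units; beyond the scatter) in this assay. Within the data shown here, the earlier compounds all end in hydroxycarbamoyl, so this is the first sign that a compound without that end can still give a lower number, although the chain and its end group change together in this step. Nothing shown here explains the change.

The compounds shown leave open how much of the step comes from the longer chain and how much from the new end group. A carboxylic acid at the end of the same chain would test whether the methylcarbamoyl end itself matters.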